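From 2-fluorophenyl to 3-methylphenyl on the shared core

The source may report more compounds than this note shows. Statements on the series, on what has been measured and on what is new or still open speak of the compounds shown alone.

Three compounds have readings so far in an ADME assay on CHO cells (Cricetulus griseus) for cytotoxicity, read by LDH release (on this read-out lower numbers stand for stronger inhibition and higher numbers for weaker inhibition), on this series. Compound 1 (`CC(Nc1ccc(Cl)cc1Cl)C(=O)NCc1ccc(F)cc1`) gives > 100000 nM here, and this is a limit of the assay, not a number. Compound 2 (`CC(Oc1ccc(Cl)cc1Cl)C(=O)NC(c1ccc(F)cc1)C(C)C`) gives > 100000 nM here, again a limit only. For the measured compounds named here, compound 3 (`CC(Oc1ccc(Cl)cc1Cl)C(=O)NCc1ccccc1F`) gives 47000 nM as the only true number in the set. Compound 4 (`Cc1cccc(CNC(=O)C(C)Oc2ccc(Cl)cc2Cl)c1`) departs from compound 3 in one place: 3-methylphenyl in place of 2-fluorophenyl on a saturated chain carbon bound to an amide-type nitrogen puts 3-methylphenyl in place of 2-fluorophenyl on a saturated chain carbon bound to an amide-type nitrogen. Going by the values given here, no measured pair isolates a change of this kind, so the data give no direct guide to its size. The expectation is for no shift beyond the scatter in this assay and at most a slight lean toward weaker inhibition. The estimated move a 1.2-fold higher number from compound 3 to compound 4 (0.07 log units; within the scatter) is expected to stay small. Compound 4 is estimated at 55000 nM with an expected range from 25000 nM to 100000 nM in this read-out, though it may yet return only a limit.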

Compound 4, half-maximal inhibitory concentration: 45000 nM
Estimate against measurement, compound 4: 1.2-fold (0.09 log units) above; the measured number falls inside the stated range.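

In this assay, 3-methylphenyl in place of 2-fluorophenyl on a saturated chain carbon bound to an amide-type nitrogen gives a 1.0-fold lower number from compound 3 to compound 4 (0.02 log units; within the scatter). For the compounds shown here, this is the only step in the set that isolates a single change, and it shows that this place on the shared core tolerates the exchange of one substituted phenyl ring for another with no shift that can be told from the scatter. Compound 1 and compound 2 add no number to set beside this step, only a limit of the assay: the limit of > 100000 nM in this assay, at which 2 of the 4 values shown sit.

On these data alone, whether a carboxylic acid or an amine on this ring, or a longer chain in its place, would move the reading remains open. A single step also cannot show whether the same exchange would behave alike on a different core.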